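A few compounds are considered here, and "the series" means these few. Any claim that something is new, unique, unknown or untested is made for them only; others in the source may bear on it.

Working notes on a three-compound series tested in a functional assay on THP-1 cells (Homo sapiens) for cytotoxicity, read by MTT assay, with a stated time of 24 h; a higher number here means a weaker inhibitor, a lower number a stronger inhibitor. Compound 1 `Nc1nn(Cc2cn(CC(=O)Nc3ccccc3)nn2)c2nc(-c3ccccc3)cc(C(F)(F)F)c12` gives 54.6 ug/mL. Compound 2 `Nc1nn(Cc2cn(CC(=O)Nc3cccc(F)c3)nn2)c2nc(-c3ccccc3)cc(C(F)(F)F)c12` carries the change fluoro in place of hydrogen on an aromatic carbon relative to compound 1, and the step is a 1.8-fold higher number from compound 1 to compound 2 (0.26 log units; within the scatter). Compound 3 `Nc1nn(Cc2cn(CC(=O)Nc3ccccc3Br)nn2)c2nc(-c3ccccc3)cc(C(F)(F)F)c12` differs from compound 1 by bromo in place of hydrogen on an aromatic carbon, with the step of a 1.7-fold higher number from compound 1 to compound 3 (0.24 log units; within the scatter); in this assay compound 2 gives 99.5 ug/mL and compound 3 gives 95.3 ug/mL, and between them the step is a 1.0-fold lower number from compound 2 to compound 3 (0.02 log units; within the scatter). All three numbers sit within the scatter of one another, so no order among compounds 1, 2 and 3 can be read from them.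

Compound 4 `Nc1nn(Cc2cn(CC(=O)Nc3ccc(F)cc3Br)nn2)c2nc(-c3ccccc3)cc(C(F)(F)F)c12` is not yet measured. Among the measured compounds shown here, it differs from compound 3 by fluoro in place of hydrogen on an aromatic carbon, the same kind of change as the one from compound 1 to compound 2, though not the same: in compound 2 the fluoro sits meta to a large group, whereas in compound 4 it sits meta to a bromo group and para to a large group. The cores of the two pairs differ by bromo in place of hydrogen on an aromatic carbon.

The expected step is a 1.2-fold higher number from compound 3 to compound 4 (0.06 log units; within the scatter), set beside the earlier 1.8-fold higher number from compound 1 to compound 2 (0.26 log units; within the scatter), and it is estimated small because the earlier fluoro step a 1.8-fold higher number from compound 1 to compound 2 (0.26 log units; within the scatter) stayed within the scatter. For compound 4 the estimate in this assay is 110 ug/mL, expected to fall between 60 ug/mL and 200 ug/mL.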

Compound 4, half-maximal inhibitory concentration: 65.6 ug/mL
Estimate against measurement, compound 4: 1.7-fold (0.22 log units) above, within the range that was stated.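

In this assay the change of fluoro in place of hydrogen on an aromatic carbon can be compared on two cores, that of compound 1 and that of compound 3: the same change on two cores in this assay, a 1.8-fold higher number (0.26 log units; within the scatter) from compound 1 to compound 2 and a 1.5-fold lower number (0.16 log units; within the scatter) from compound 3 to compound 4, 2.6-fold (0.42 log units) apart, within the scatter of two such steps. The new step is a 1.5-fold lower number from compound 3 to compound 4 (0.16 log units; within the scatter), and the other two steps that reach the new compound, a 1.5-fold lower number from compound 2 to compound 4 (0.18 log units; within the scatter) and a 1.2-fold higher number from compound 1 to compound 4 (0.08 log units; within the scatter), also stay within the scatter, so compound 4 joins the other three compounds with no order among them. Among the compounds shown here, this shows no detectable difference in how the change behaves on the two cores, but it does not show that the change carries over, since neither fluoro step is beyond the scatter, each core contributes a single pair, and the fluoro on compound 4 sits para to a large group and meta to a bromo group, a placement that has no exact counterpart on the core of compound 1.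

The compounds shown leave open whether a group other than a halogen on this phenyl ring, such as an amine or a carboxylic acid, would give a step beyond the scatter in this assay. Also open, as far as these compounds go, is what a longer chain in place of the phenyl on the amide-type nitrogen would do.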